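Dropping the methylsulfonyl-bearing substituent: solubility notes

This account rests on a few compounds, and the source may have more. Where it says the series, first, only, none or still open, it means among the compounds named here.

Compound 1 `CC(C)(c1cc([C@@]23CCOC[C@@H]2C3)nc(-c2cccc(O)c2)n1)S(C)(=O)=O` and compound 2 `Oc1cccc(-c2nccc([C@@]34CCOC[C@@H]3C4)n2)c1` share a core; in a physicochemical assay for solubility, in phosphate buffer, measured as kinetic solubility, with a stated time of 1 h, at pH 7.4 (a higher number here means a more soluble compound, a lower number a less soluble compound), compound 1 gives 148 ug/mL and compound 2 gives 123 ug/mL. The change between them, (hydrogen in place of 1-methyl-1-(methylsulfonyl)ethyl on an aromatic carbon), made a step of a 1.2-fold lower number from compound 1 to compound 2 (0.08 log units; within the scatter). Compound 3 `CCNC(=O)Nc1ccc(-c2nc(C(C)(C)S(C)(=O)=O)cc([C@@]34CCOC[C@@H]3C4)n2)cc1` gives 78 ug/mL in this assay; how its core differs from the core of compound 1 is not broken down here. Compound 4 `CCNC(=O)Nc1ccc(-c2nccc([C@@]34CCOC[C@@H]3C4)n2)cc1` is not yet measured and arises from compound 3 by hydrogen in place of 1-methyl-1-(methylsulfonyl)ethyl on an aromatic carbon. This is the same kind of change as the one above, though the surroundings differ: in compound 1 the place is meta to a 3-hydroxyphenyl group (7 heavy atoms), in compound 3 meta to a large group. Compound 4 is expected to sit near 68 ug/mL, a step of a 1.1-fold lower number from compound 3 to compound 4 (0.06 log units; within the scatter), resting on compound 3 at 78 ug/mL and on the earlier step of a 1.2-fold lower number from compound 1 to compound 2 (0.08 log units; within the scatter) having stayed within the scatter.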

Compound 4, solubility: 127 ug/mL
Compound 4: the middle estimate sits 1.9-fold (0.27 log units) below what was measured; the range from low to high includes it.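

In this assay the step of a 1.6-fold higher number from compound 3 to compound 4 (0.21 log units; within the scatter) lies within the scatter, and so does the step of a 1.2-fold lower number from compound 1 to compound 2 (0.08 log units; within the scatter) on the other core, so neither can be told apart from repeat measurement. Hydrogen in place of 1-methyl-1-(methylsulfonyl)ethyl thus gives no step beyond the scatter on these two cores, but this does not show that the two steps are equal, that the change has no effect, or that the result would hold on a third core. Nothing at hand bears on the reason for these numbers.

Open, going by these compounds, is whether an amine or a carboxylic acid at that place would give a step beyond the scatter. Open too, on these data alone, is whether either group would behave alike on both cores.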